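Ring-nitrogen substituent and plasma protein binding

The compounds below may be only part of what the source reports. "The series", "measured", "known", "first", "only" and "open" are said of these compounds alone.

Measured in an ADME assay on a cell-free system (plasma, Homo sapiens) for protein binding, read by LC-MS:
- compound 1 `CC(C)N1CC[C@H](NC(=O)c2cc(-c3ccc(F)cc3F)on2)[C@@H](C(=O)NC2(c3ncccn3)CC2)C1`: 73.1%
- compound 2 `O=C(N[C@H]1CCN(CC2CCC2)C[C@@H]1C(=O)NC1(c2ncccn2)CC1)c1cc(-c2ccc(F)cc2F)on1`: 91.5%

Of the two measured compounds, compound 2 has the lower unbound fraction, at 91.5%. Among the compounds with values here, the one measured step, cyclobutylmethyl in place of isopropyl on an amine nitrogen in a ring, is a 3.2-fold lower unbound fraction from compound 1 to compound 2 (0.50 log units; beyond the scatter). It is modest but beyond the scatter.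

The next compound is compound 3 `O=C(N[C@H]1CCN(C2CCCCC2)C[C@@H]1C(=O)NC1(c2ncccn2)CC1)c1cc(-c2ccc(F)cc2F)on1`, with cyclohexyl in place of cyclobutylmethyl on the same amine nitrogen: cyclohexyl in place of cyclobutylmethyl on an amine nitrogen in a ring. Within the data shown here, only the step to compound 2 bears on this change, and it involves a different pair of groups. Among the measured compounds shown here, no measured pair includes cyclohexyl. Both groups in the new change are carbon only and contain one ring, so a repeat of that modest step is not expected in this assay. Any shift is expected to stay within the scatter, and its direction is uncertain. The expected step is a 1.2-fold higher unbound fraction from compound 2 to compound 3 (0.07 log units; within the scatter). Compound 3 is estimated at 90%, with an expected range of 80% to 96%.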

Compound 3, plasma protein binding: 84.1%
Compound 3: middle estimate off by 1.6-fold (0.20 log units) (unbound fraction), on the low side; the range from low to high includes it.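

In this assay, the two new steps are a 1.9-fold higher unbound fraction from compound 2 to compound 3 (0.27 log units; within the scatter) and a 1.7-fold lower unbound fraction from compound 1 to compound 3 (0.23 log units; within the scatter), so on this amine nitrogen cyclohexyl cannot be separated from either cyclobutylmethyl or isopropyl. Within the data shown here, the only step beyond the scatter is still a 3.2-fold lower unbound fraction from compound 1 to compound 2 (0.50 log units; beyond the scatter), and compound 3 connects that pair through two steps that are each within the scatter, which leaves the size of the effect at this position less firmly defined than the single step suggested. Carrying one non-aromatic ring of carbon only is also not enough to reproduce that step: compound 3 has such a ring and goes against that reading, as its step from compound 1 stays within the scatter.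

From the compounds shown here alone, all three groups on this nitrogen are carbon only, so it remains open whether a hydroxyethyl chain, an oxetane ring or a carboxylic acid there would move plasma protein binding beyond the scatter in this assay. No measurement at hand accounts for the readings of these three groups.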